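The source may hold more compounds than are shown below. What is called first, only, known or untested is meant among the compounds shown, and "the series" means these compounds.

Among the compounds with values here, compound 1 `Oc1cccc(-c2cc(-c3ccc(Cl)cc3)nc(-c3ccsc3)c2)c1` gives 11600 nM in a functional assay on DU-145 cells (Homo sapiens) for cytotoxicity, read by CCK-8 assay and cell counting, with a stated time of 2 days (a higher number here means a weaker inhibitor, a lower number a stronger inhibitor), the highest of the three numbers measured so far. Compound 2 `Oc1cccc(-c2cc(-c3ccsc3)nc(-c3ccccc3Cl)c2)c1` gives 1970 nM and compound 3 `Oc1cccc(-c2cc(-c3ccsc3)nc(-c3cccc(Cl)c3)c2)c1` gives 3330 nM; the steps of a 5.9-fold lower number from compound 1 to compound 2 (0.77 log units; beyond the scatter) and a 3.5-fold lower number from compound 1 to compound 3 (0.54 log units; beyond the scatter) both move only the chlorine on the chlorophenyl ring, while a 1.7-fold higher number from compound 2 to compound 3 (0.23 log units; within the scatter). Compound 4 `Oc1cccc(-c2cc(-c3ccncc3)nc(-c3ccc(Cl)cc3)c2)c1` keeps the 4-chlorophenyl of compound 1 and alters a different ring: pyridin-4-yl in place of thiophen-3-yl on an aromatic carbon. Within the data shown here, no measured step exchanges this ring, so the three steps give no direction for it; a change beyond the scatter cannot be expected with confidence in either direction, and the range must stay wide. Compound 4 is therefore estimated at 8000 nM (2000 nM to 30000 nM), an expected step of a 1.5-fold lower number from compound 1 to compound 4 (0.16 log units; within the scatter).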

Compound 4, half-maximal inhibitory concentration: 2510 nM
For compound 4 the middle estimate is 3.2-fold (0.50 log units) above the measured one, within the range that was stated.
By their numbers in this assay, from the lowest: compounds 2, 4 and 3 (each within the scatter of the next); then compound 1.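

With the 4-chlorophenyl group kept, pyridin-4-yl in place of thiophen-3-yl gives a 4.6-fold lower number from compound 1 to compound 4 (0.66 log units; beyond the scatter) in this assay, a modest step. Within the data shown here, the position next to the ring nitrogen can therefore shift the number beyond the scatter, as the chlorine placement on the chlorophenyl ring did in the earlier steps. No measurement on hand explains this change.

Among these compounds, only one exchange at this position can be read, and whether it carries over to the 2-chlorophenyl or 3-chlorophenyl compounds remains open. Also open, going by these compounds, is how pyridin-3-yl, a morpholine or a primary amine would fare at this position.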